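A few compounds are considered here, and "the series" means these few. Any claim that something is new, unique, unknown or untested is made for them only; others in the source may bear on it.

Of the compounds shown here, three have been measured and one remains open. Compound 1 `Oc1ccc(-c2cc(-c3ccco3)cc(-c3ccccc3O)n2)cc1`, compound 2 `Oc1ccc(-c2cc(-c3ccco3)cc(-c3cccc(O)c3)n2)cc1` and compound 3 `Oc1cccc(-c2cc(-c3ccccn3)cc(-c3ccccc3O)n2)c1` are in hand; compound 4 `Oc1cccc(-c2cc(-c3ccccn3)cc(-c3cccc(O)c3)n2)c1` completes the set. All were or will be run in a functional assay on T47D cells (Homo sapiens) for cytotoxicity, read by CCK-8 assay; on this read-out higher numbers stand for weaker inhibition and lower numbers for stronger inhibition.

Compound 1 gives only a limit in this assay, > 50000 nM, which is a limit of the measurement (the limit of > 50000 nM in this assay, at which 1 of the 3 values shown sits). Compound 2 gives 1280 nM in this assay. Compound 3 gives 2560 nM in this assay, and the values of compound 2 and compound 3 lie within the scatter of each other.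

The change from compound 1 to compound 2 is 3-hydroxyphenyl in place of 2-hydroxyphenyl on an aromatic carbon. In this assay it made an at least 39-fold lower number from compound 1 to compound 2 (1.59 log units; beyond the scatter). How the core of compound 1 and the core of compound 3 differ is not broken down here. The change from compound 3 to compound 4 is 3-hydroxyphenyl in place of 2-hydroxyphenyl on an aromatic carbon. It is the same kind of change, though the surroundings differ: in compound 1 the replaced group stands meta to a 4-hydroxyphenyl group and meta to a furan-2-yl group, whereas in compound 3 it stands meta to a 3-hydroxyphenyl group and meta to a pyridin-2-yl group.

Resting on the step from compound 1 to compound 2, an at least 39-fold lower number from compound 1 to compound 2 (1.59 log units; beyond the scatter), one expects a step of a 5.1-fold lower number from compound 3 to compound 4 (0.71 log units; beyond the scatter) in this assay, smaller than the earlier one since compound 3 already gives a number, 2560 nM, rather than a limit. Compound 4 is therefore expected to come out near 500 nM in this assay, estimated between 100 nM and 2500 nM.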

Compound 4, half-maximal inhibitory concentration: 1410 nM
For compound 4 the middle estimate is 2.8-fold (0.45 log units) below the measured one; the range from low to high includes it.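

On the core of compound 3, in this assay, 3-hydroxyphenyl in place of 2-hydroxyphenyl gave a 1.8-fold lower number from compound 3 to compound 4 (0.26 log units; within the scatter), so here the change left the number within the usual scatter. Set beside the earlier step, the same change did not carry over in size from one core to the other: the same change on two cores in this assay, an at least 39-fold lower number (1.59 log units; beyond the scatter) from compound 1 to compound 2 and a 1.8-fold lower number (0.26 log units; within the scatter) from compound 3 to compound 4, at least 21-fold (1.33 log units) apart, beyond the scatter of two such steps

What this does not show is which difference between the core of compound 1 and the core of compound 3 goes with the gap, and the true size of the earlier step also stays open, as compound 1 gives only a limit: the limit of > 50000 nM in this assay, at which 1 of the 4 values shown sits.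

The compounds shown leave open how each difference between the two cores acts on its own, for instance what pyridin-2-yl in place of furan-2-yl would do with the other groups held the same. They also leave open whether a methoxy group or an amine in place of the hydroxyl on these phenyl rings would keep the numbers seen for compound 2 and compound 4 in this assay.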